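This account rests on a few compounds, and the source may have more. Where it says the series, first, only, none or still open, it means among the compounds named here.

Compound 1 `CC(C)C1Sc2nnc(-c3[nH]nc4c3CCC4)n2N=C1c1ccc(Cl)c(Cl)c1` gives, in a functional assay on CAL-33 cells (Homo sapiens) for inhibition (a lower number here means a stronger inhibitor of growth, a higher number a weaker inhibitor of growth), a value of 8200 nM. The two other measured compounds share the same core but carry different groups: compound 2 `CC1Sc2nnc(-c3cc(-c4ccc(F)cc4)n[nH]3)n2N=C1c1ccccc1` gives 36300 nM, and compound 3 `CC1Sc2nnc(-c3cc(-c4ccccc4)n[nH]3)n2N=C1c1ccccc1` gives 34100 nM. Compound 1 thus has the lowest number of the three, beyond the scatter of both others. Within the data shown here, the only measured step, a 1.1-fold lower number from compound 2 to compound 3 (0.03 log units; within the scatter), touches a distant aromatic ring and says nothing about the saturated ring carbon. Compound 4 `Clc1ccc(C2=Nn3c(nnc3-c3[nH]nc4c3CCC4)SC2Cc2ccccc2)cc1Cl` differs from compound 1 by benzyl in place of isopropyl on a saturated ring carbon. Among the measured compounds shown here, no measured step bears on this change, so the expectation rests on compound 1 alone; compound 4 is estimated at 8000 nM, within 2000 nM to 32000 nM, which means an expected step of a 1.0-fold lower number from compound 1 to compound 4 (0.01 log units; within the scatter).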

Compound 4, concentration for 50% growth inhibition: 3300 nM
The estimate for compound 4 lay 2.4-fold (0.38 log units) above the measured number; measured number inside the range.
By their numbers in this assay, from the lowest: compound 4; then compound 1; then compounds 3 and 2 (each within the scatter of the next).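

In this assay the saturated ring carbon next to the ring sulfur tolerates a group carrying an aromatic ring, and there is a 2.5-fold lower number from compound 1 to compound 4 (0.40 log units; beyond the scatter) on moving to benzyl. Among these compounds, this modest gain is the first sign that this position can influence growth inhibition. Nothing available explains the change.

From the compounds shown here alone, whether the gain comes from the aromatic ring itself or simply from a bigger group remains open. A cyclohexylmethyl group or a longer alkyl chain at this carbon would help separate these, and an amine on the benzyl ring would test whether the ring tolerates further substitution.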